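Bromo in Place of Chloro: Compound 3 Expected

The source may report more compounds than this note shows. Statements on the series, on what has been measured and on what is new or still open speak of the compounds shown alone.

Compound 1 `C=CC(=O)Nc1cccc(NC(=O)CSc2nc(Nc3cccc(F)c3)c3ccccc3n2)c1`: 5370 nM
Compound 2 `C=CC(=O)Nc1cccc(NC(=O)CSc2nc(Nc3ccc(Cl)cc3)c3ccccc3n2)c1`: 10800 nM

In a functional assay on PC-3 cells (Homo sapiens) for inhibition, read by MTT assay, with a stated time of 72 h (a lower number here means a stronger inhibitor, a higher number a weaker inhibitor), compound 2 gives 10800 nM, the higher of the two numbers, while compound 1 gives 5370 nM; the step of a 2.0-fold higher number from compound 1 to compound 2 (0.30 log units; within the scatter) lies within the scatter. Compound 3 `C=CC(=O)Nc1cccc(NC(=O)CSc2nc(Nc3ccc(Br)cc3)c3ccccc3n2)c1` carries bromo in place of chloro on an aromatic carbon. Among the compounds with values here, no measured step exchanges one halogen for another at the same place; the single step of a 2.0-fold higher number from compound 1 to compound 2 (0.30 log units; within the scatter) alters both the halogen and its place and stays within the scatter. Compound 3 is therefore expected to move little, by a 1.1-fold lower number from compound 2 to compound 3 (0.03 log units; within the scatter), with an estimated 10000 nM in a range of 4000 nM to 25000 nM.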

Compound 3, half-maximal inhibitory concentration: 12400 nM
For compound 3 the middle estimate is 1.2-fold (0.09 log units) below the measured one, and the stated range covers the measured number.
By their numbers in this assay, from the lowest: compounds 1, 2 and 3 (each within the scatter of the next, the first and the last beyond it).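

Bromo and chloro on this aromatic carbon, para to a large group, cannot be told apart in this assay, where the exchange gives a 1.1-fold higher number from compound 2 to compound 3 (0.06 log units; within the scatter) and so provides the first same-place halogen comparison. Replacing 3-fluorophenyl with 4-bromophenyl, which alters both halogen and place, gives a 2.3-fold higher number from compound 1 to compound 3 (0.36 log units; beyond the scatter) and is a modest step beyond the scatter. Nothing available explains either step.

On these data alone, whether an amine or a carboxylic acid at this place would move the number stays open. So does whether the halogen's identity or its place underlies the step between the fluoro and bromo compounds.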